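This account rests on a few compounds, and the source may have more. Where it says the series, first, only, none or still open, it means among the compounds named here.

Three compounds of a shared core were measured in an assay for binding affinity to Corticotropin releasing factor receptor (Rattus norvegicus); a higher number here means a weaker inhibitor, a lower number a stronger inhibitor. Compound 2 `CCc1nc2c(-c3ccc(Cl)cc3Cl)ccnc2n1C(C)C1CCC1` gives 1 nM, the lowest of the three numbers. Compound 1 `CCCC(C)n1c(CC)nc2c(-c3ccc(/C(C)=N\OC)cc3Cl)ccnc21` gives 2.3 nM, and compound 3 `CCCC(C)n1c(CC)nc2c(-c3ccc(S(C)(=O)=O)cc3C(F)(F)F)ccnc21` gives 6.8 nM; both steps from compound 2 lie beyond the scatter, so compound 2 is the strongest binder here. Compound 4 `CCc1nc2c(-c3ccc(Cl)cc3Cl)ccnc2n1C(CC)CC` has not yet been measured. It differs from compound 2 in one place: pentan-3-yl in place of 1-cyclobutylethyl on an aromatic nitrogen. Among the compounds with values here, no measured pair shows this exact exchange. A small weakening, or no step beyond the scatter, is expected from compound 2 in this assay, a 1.8-fold higher number from compound 2 to compound 4 (0.26 log units; within the scatter). Compound 4 is therefore estimated at 1.8 nM, between 0.7 nM and 5 nM.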

Compound 4, inhibition constant: 1 nM
Compound 4: the middle estimate sits 1.8-fold (0.26 log units) above what was measured; low and high end bracket the measured number.
By their numbers in this assay, from the lowest: compounds 2 and 4 (each within the scatter of the next); then compound 1; then compound 3.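

In this assay, pentan-3-yl in place of 1-cyclobutylethyl on the aromatic nitrogen gives no change at the digits printed from compound 2 to compound 4 (within the scatter). At this position, then, the four-membered carbon ring can give way to an open chain with no ring, and binding stays in the same range. Nothing measured here explains why these two groups match.

On these data alone, whether the position also tolerates a larger ring such as cyclohexyl, or a chain carrying an amine or a methoxy group, stays open. Within the data shown here, this exchange is also seen in only one pair, on the core of compound 2.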